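Paired aryl swap in two related urea series

This account rests on a few compounds, and the source may have more. Where it says the series, first, only, none or still open, it means among the compounds named here.

Measured compounds:
compound 1, `CCNc1cc(-c2ccc(NC(=O)Nc3cccc(Cl)c3)cc2C)ccn1`, with 16600 nM in a functional assay on BT-483 cells (Homo sapiens) for cytotoxicity, read by MTT assay, with a stated time of 24 h; on this read-out higher numbers stand for weaker inhibition and lower numbers for stronger inhibition
compound 2, `CCNc1cc(-c2ccc(NC(=O)Nc3ccc(C(F)(F)F)cc3)cc2C)ccn1`, with 19700 nM in this assay
compound 3, `O=C(Nc1cccc(Cl)c1)Nc1ccc(-c2ccnc(NCC3CC3)c2)c(C(F)(F)F)c1`

In this assay compound 3 reaches only the limit of the assay, > 30000 nM, and no number is obtained; this is the limit described as the limit of > 30000 nM in this assay, at which 1 of the 3 values shown sits. The difference between the core of compound 1 and the core of compound 3 is not broken down here.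

Compound 2 arises from compound 1 by 4-(trifluoromethyl)phenyl in place of 3-chlorophenyl on an amide-type nitrogen. In this assay this gives a 1.2-fold higher number from compound 1 to compound 2 (0.07 log units; within the scatter). The unmeasured compound 4, `O=C(Nc1ccc(C(F)(F)F)cc1)Nc1ccc(-c2ccnc(NCC3CC3)c2)c(C(F)(F)F)c1`, arises from compound 3 by the same change, (4-(trifluoromethyl)phenyl in place of 3-chlorophenyl on an amide-type nitrogen), at the same place.

Because the first occurrence of this change gave a 1.2-fold higher number from compound 1 to compound 2 (0.07 log units; within the scatter), and compound 3 already sits at the limit described as the limit of > 30000 nM in this assay, at which 1 of the 3 values shown sits, a step that the limit leaves unreadable from compound 3 to compound 4 is expected from compound 3 to compound 4. Compound 4 is therefore estimated at 36000 nM in this assay, most probably reported again as a limit rather than a number.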

Compound 4, half-maximal inhibitory concentration: > 30000 nM
Compound 4 ended at the assay's limit (the forecaster's own chance of this, stated with the estimate: 70%); the middle value does not contradict the limit.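

In this assay compound 4 gives > 30000 nM as a limit of the assay and not a number. Compound 3 stands at that same limit, so no step can be read from compound 3 to compound 4: the limit of > 30000 nM in this assay, at which 2 of the 4 values shown sit. The compounds shown leave open whether 4-(trifluoromethyl)phenyl in place of 3-chlorophenyl changes the read-out at all on the core of compound 3.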